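This account rests on a few compounds, and the source may have more. Where it says the series, first, only, none or still open, it means among the compounds named here.

Measured compounds:
- Compound 1 `CC[C@H](C)[C@H](NC(=O)c1cccc(Cn2ccnc2)c1)C(=O)Nc1nccs1`: 42000 nM
- Compound 3 `CC[C@H](C)[C@H](NC(=O)c1cccc(Cn2ccnc2)c1)C(=O)NNS(=O)(=O)c1ccc(OC)cc1`: 9200 nM
- Compound 2 `CCCCNC(=O)[C@@H](NC(=O)c1cccc(Cn2ccnc2)c1)[C@@H](C)CC`: "not determined" (no result reported)

In an assay on HEK293 cells for displacement of a labelled ligand from Type-2 angiotensin II receptor (Homo sapiens) (on this read-out lower numbers stand for stronger inhibition and higher numbers for weaker inhibition), compound 1 gives 42000 nM, and compound 3 gives 9200 nM, so of these two, compound 3 is the stronger inhibitor. Compound 2 stands nowhere on the numbers: for it this assay gives "not determined" (no result reported). Compound 4 `CCCCCS(=O)(=O)NNC(=O)[C@@H](NC(=O)c1cccc(Cn2ccnc2)c1)[C@@H](C)CC` differs from compound 2 by (pentylsulfonyl)amino in place of butyl on an amide-type nitrogen. Since compound 2 carries no number, no direction or size of step in this assay can be stated for it. Compound 4 resembles compound 3 in its (pentylsulfonyl)amino part, and its inhibition constant in this assay is therefore expected to lie near that of compound 3, estimated at 12000 nM with a range from 3000 nM to 50000 nM.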

Compound 4, inhibition constant: > 100000 nM
Compound 4 was reported as a limit; the forecaster's own chance of this, stated with the estimate: 15%; middle value at least 8.3-fold (0.92 log units) away from the limit.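

In this assay the value of compound 4 is a limit and not a number: the limit of > 100000 nM in this assay, at which 1 of the 4 values shown sits. On a sulfonyl sulfur, pentyl in place of 4-methoxyphenyl gives an at least 10-fold higher number from compound 3 to compound 4 (1.03 log units; beyond the scatter), so the sulfonylamino link shared by these two compounds does not by itself set the read-out; the group on the sulfur matters. On an amide-type nitrogen, (pentylsulfonyl)amino in place of 1,3-thiazol-2-yl gives an at least 2.3-fold higher number from compound 1 to compound 4 (0.37 log units; beyond the scatter).

From the compounds shown here alone, whether the loss follows from the pentyl chain or from the absence of a ring on the sulfur stays open. Methyl or unsubstituted phenyl on the sulfur could separate these two readings.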